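The source may report more compounds than this note shows. Statements on the series, on what has been measured and on what is new or still open speak of the compounds shown alone.

Of the compounds shown here, three share one core and have been tested in an assay on isolated protein for inhibition of Indoleamine 2,3-dioxygenase 1 (Homo sapiens), read by colorimetric assay, with stated times of 10 min and 30 min, tested at 100 uM; on this read-out lower numbers stand for less inhibition and higher numbers for more inhibition at the one concentration tested (going by the name of the read-out). Compound 1, `Fc1ccccc1-c1c[nH]c(=S)s1`, gives 29%. Compound 2, `COc1ccccc1-c1csc(=S)[nH]1`, gives 53%. Compound 3, `Fc1ccccc1-c1csc(=S)[nH]1`, gives 77% and stands highest of the three, with compound 2 nearest and compound 1 furthest, both gaps beyond the scatter. For the measured compounds named here, only one step between neighbours is known: a number 24 percentage points higher from compound 2 to compound 3 (beyond the scatter).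

The next compound, compound 4, `O=C(O)c1ccccc1-c1csc(=S)[nH]1`, differs from compound 3 in one place: carboxy in place of fluoro on an aromatic carbon. The step from compound 2 to compound 3 is the only one that bears on this change, and it concerns the same position on the ring. It shows that exchanging the group on that carbon can move the read-out by a modest amount in this assay. Going by the values given here, since the earlier exchange toward fluoro raised the number, moving away from fluoro is expected to lower it, though carboxy has no direct precedent here, so the range is wide. The expected step is a number 32 percentage points lower from compound 3 to compound 4 (beyond the scatter). For compound 4 the estimate is 45%, between 15% and 75%.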

Compound 4, a percentage reported as inhibition, at one concentration (the size of the read-out at that concentration, not a potency): 8%
The estimate for compound 4 lay 37 percentage points above the measured number, and the stated range ends above it.
By their numbers in this assay, from the lowest: compound 4; then compound 1; then compound 2; then compound 3.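

In this assay, for the compounds shown here, the group on this aromatic carbon turns out to matter more than the earlier compounds could show: carboxy in place of fluoro brings a number 69 percentage points lower from compound 3 to compound 4 (beyond the scatter) and carboxy in place of methoxy brings a number 45 percentage points lower from compound 2 to compound 4 (beyond the scatter) and both steps are large. Among the three compounds that differ only at this carbon, the order from highest to lowest is now fluoro, methoxy, carboxy, so the earlier modest step did not mark the full spread at this position. Nothing at hand explains why carboxy gives the lowest number of the three.

From the compounds shown here alone, it remains open how a hydroxy group, an amine or a methyl ester on this same carbon would compare with carboxy. Also open is whether the same order holds on the core of compound 1, which is shown here with fluoro alone.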